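Replacing a benzoxazole thioether with an ethylpiperazine

The source may report more compounds than this note shows. Statements on the series, on what has been measured and on what is new or still open speak of the compounds shown alone.

Three compounds share one core and were tested in a functional assay on HT-29 cells (Homo sapiens) for cytotoxicity, read by MTT assay, with a stated time of 24 h; a lower number here means a stronger inhibitor, a higher number a weaker inhibitor. Compound 1 `Cn1c(-c2ccc(NC(=O)CCl)cc2)nc(-c2ccccc2)c1-c1ccccc1` gives 28.7 ug/mL, compound 2 `Cc1ccc2oc(SCC(=O)Nc3ccc(-c4nc(-c5ccccc5)c(-c5ccccc5)n4C)cc3)nc2c1` gives 22.4 ug/mL, and compound 3 `CN1CCN(CC(=O)Nc2ccc(-c3nc(-c4ccccc4)c(-c4ccccc4)n3C)cc2)CC1` gives 35.5 ug/mL. Compound 2 has the lowest number of the three, yet the steps of a 1.3-fold lower number from compound 1 to compound 2 (0.11 log units; within the scatter) and a 1.6-fold higher number from compound 2 to compound 3 (0.20 log units; within the scatter) both lie within the scatter, so no ordering can be claimed. Compound 4 `CCN1CCN(CC(=O)Nc2ccc(-c3nc(-c4ccccc4)c(-c4ccccc4)n3C)cc2)CC1` differs from compound 2 by 4-ethylpiperazin-1-yl in place of (5-methyl-1,3-benzoxazol-2-yl)sulfanyl on a saturated chain carbon bound to a carbonyl carbon. The closest guide is compound 3, which carries the methyl homologue of the entering group; its step of a 1.6-fold higher number from compound 2 to compound 3 (0.20 log units; within the scatter) and the step of a 1.2-fold higher number from compound 1 to compound 3 (0.09 log units; within the scatter) were both within the scatter. Accordingly, no change beyond the scatter is expected, and compound 4 is estimated at 33 ug/mL, between 18 ug/mL and 60 ug/mL, a step of a 1.5-fold higher number from compound 2 to compound 4 (0.17 log units; within the scatter).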

Compound 4, half-maximal inhibitory concentration: 75 ug/mL
The estimate for compound 4 lay 2.3-fold (0.36 log units) below the measured number; the measured number lies above the stated range.
By their numbers in this assay, from the lowest: compounds 2, 1 and 3 (each within the scatter of the next); then compound 4.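

In this assay, within the data shown here, this place, on a saturated chain carbon bound to a carbonyl carbon, now shows steps beyond the scatter, which no earlier pair did (a 3.3-fold higher number from compound 2 to compound 4 (0.52 log units; beyond the scatter)) and (a 2.6-fold higher number from compound 1 to compound 4 (0.42 log units; beyond the scatter)). Even methyl in place of hydrogen on a saturated chain carbon bound to an amine nitrogen in a ring counts here (a 2.1-fold higher number from compound 3 to compound 4 (0.32 log units; beyond the scatter)), so 4-methylpiperazin-1-yl does not stand in for 4-ethylpiperazin-1-yl. Nothing available explains this gap. From the compounds shown here alone, whether a longer chain, such as 4-propylpiperazin-1-yl, would raise the number further remains open, as does the result for plain piperazin-1-yl, with hydrogen in place of the ethyl.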